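Changing the benzyl group on compound 3

The compounds below may be only part of what the source reports. "The series", "measured", "known", "first", "only" and "open" are said of these compounds alone.

Measured in a functional assay on A549 cells (Homo sapiens) for antiproliferative activity, read by MTT assay, with a stated time of 48 h; on this read-out higher numbers stand for weaker inhibition and lower numbers for stronger inhibition:
compound 1 `O=[N+]([O-])c1cc(C(F)(F)F)cc([N+](=O)[O-])c1Oc1ccccc1/C=N\OCc1ccccc1F`: 860 nM
compound 2 `O=[N+]([O-])c1cc(C(F)(F)F)cc([N+](=O)[O-])c1Oc1ccc(Cl)cc1/C=N\OCc1ccc(Cl)cc1Cl`: 3440 nM
compound 3 `O=[N+]([O-])c1cc(C(F)(F)F)cc([N+](=O)[O-])c1Oc1ccc(Br)cc1/C=N\OCc1ccccc1F`: 1280 nM

Compound 3 gives 1280 nM, which lies within the scatter of compound 1 and is a clearly lower number than that of compound 2. Compound 4 `O=[N+]([O-])c1cc(C(F)(F)F)cc([N+](=O)[O-])c1Oc1ccc(Br)cc1/C=N\OCc1ccc(Cl)cc1Cl` keeps the core of compound 3 and changes one group: 2,4-dichlorophenyl in place of 2-fluorophenyl on a saturated chain carbon bound to an oxygen. Cut one bond further out, 2-fluorobenzyl becomes 2,4-dichlorobenzyl.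

Among the measured compounds shown here, the only measured step, a 1.5-fold higher number from compound 1 to compound 3 (0.17 log units; within the scatter), concerns a different place, a bromo in place of hydrogen on an aromatic carbon, and it stays within the scatter. For the measured compounds named here, no measured step covers this exchange directly. The closest guide is compound 2, which carries the same 2,4-dichlorobenzyl group with chloro instead of bromo on the core and gives 3440 nM. A move towards that number is therefore expected in this assay, meaning weaker inhibition, and the expected step is a 2.2-fold higher number from compound 3 to compound 4 (0.34 log units; beyond the scatter). The estimate for compound 4 is 2800 nM, with an expected range from 1300 nM to 6000 nM.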

Compound 4, half-maximal inhibitory concentration: 2060 nM
For compound 4 the middle estimate is 1.4-fold (0.13 log units) above the measured one, and the stated range covers the measured number.
By their numbers in this assay, from the lowest: compounds 1, 3, 4 and 2 (each within the scatter of the next, the first and the last beyond it).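

In this assay, among the compounds shown here, the 2-fluorobenzyl to 2,4-dichlorobenzyl exchange on the bromo core gives a 1.6-fold higher number from compound 3 to compound 4 (0.21 log units; within the scatter), the first direct reading at this position, and that step stays within the usual scatter. With 2,4-dichlorobenzyl held fixed, bromo in place of chloro on the core gives a 1.7-fold lower number from compound 2 to compound 4 (0.22 log units; within the scatter), which also stays within the scatter, so neither of these two single exchanges separates its pair of compounds on this read-out. No measurement shown here accounts for these results.

The benzyl groups shown carry only fluoro or chloro, so the outcome with a methoxy group or an amine on that ring, or with a longer chain in place of the benzyl group, remains open. Also open, from the compounds shown here alone, is how 2,4-dichlorobenzyl reads on the core of compound 1, which has hydrogen where compound 3 has bromo.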